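The compounds below may be only part of what the source reports. "The series", "measured", "known", "first", "only" and "open" are said of these compounds alone.

Of the compounds shown here, three sharing one core have been measured in a functional assay on PC-3 cells (Homo sapiens) for antiproliferative activity, read by MTT assay, tested at 5 uM; on this read-out higher numbers stand for a stronger effect at the one concentration tested and lower numbers for a weaker effect. Compound 1, `COc1cc(C2=NN(C(C)=O)C(c3cc(Cl)cc(Cl)c3)O2)cc(OC)c1OC`, gives 93.9%. Compound 2, `COc1ccc(C2OC(c3cc(OC)c(OC)c(OC)c3)=NN2C(C)=O)c(OC)c1`, gives 92%. Compound 3, `COc1cc(C2=NN(C(C)=O)C(c3ccc(F)c(F)c3)O2)cc(OC)c1OC`, gives 46.9%, the lowest of the three numbers: the steps that reach it are a number 45.1 percentage points lower from compound 2 to compound 3 (beyond the scatter) and a number 47 percentage points lower from compound 1 to compound 3 (beyond the scatter), both beyond the scatter, while a number 1.9 percentage points lower from compound 1 to compound 2 (within the scatter) lies within it. All three differ only in the aryl group on a saturated ring carbon of the shared core.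

The next compound, compound 4, is `COc1cc(C2=NN(C(C)=O)C(c3cccc(C(F)(F)F)c3)O2)cc(OC)c1OC`. It differs from compound 3 in one place: 3-(trifluoromethyl)phenyl in place of 3,4-difluorophenyl on a saturated ring carbon. Among the compounds with values here, no measured step involves 3-(trifluoromethyl)phenyl, so the guidance is indirect. The two measured steps that arrive at the 3,4-difluorophenyl of compound 3 were both large drops, so leaving that group could be expected to recover part of the lost effect, but the two groups that did so carry methoxy substituents rather than fluorine, and the new group keeps fluorine. For compound 4 the step expected is a number 18.1 percentage points higher from compound 3 to compound 4 (beyond the scatter), an increase with wide uncertainty. For compound 4 the estimate in this assay is 65%, with a range from 30% to 95%.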

Compound 4, a percentage reported as inhibition, at one concentration (the size of the read-out at that concentration, not a potency): 43.6%
Beside the measured number, compound 4's estimate is 21.4 percentage points above it, within the range that was stated.
By their numbers in this assay, from the lowest: compounds 4 and 3 (each within the scatter of the next); then compounds 2 and 1 (each within the scatter of the next).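

In this assay, the step to the new group is a number 3.3 percentage points lower from compound 3 to compound 4 (within the scatter), so moving away from the 3,4-difluorophenyl does not by itself restore the read-out, and the 3-(trifluoromethyl)phenyl, the larger of the two groups by heavy-atom count, cannot be told apart from it. The wide gap to the high pair now holds for a second fluorine-bearing group, with a number 48.4 percentage points lower from compound 2 to compound 4 (beyond the scatter) and a number 50.3 percentage points lower from compound 1 to compound 4 (beyond the scatter), so the four aryl groups at this saturated ring carbon fall into two pairs: 3,5-dichlorophenyl and 2,4-dimethoxyphenyl high, the two fluorine-bearing groups low. No measurement shown here explains why the groups divide in this way.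

As far as these compounds go, whether fluorine itself marks the low pair, or the placing of the substituents on the ring does, stays open, since the high and low pairs differ in both. A 3,5-difluorophenyl would keep the substituent placing of compound 1 while changing the halogen, and a plain phenyl would show the level of the shared core with no substituent on this ring at all.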